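The source may hold more compounds than are shown below. What is called first, only, known or untested is meant among the compounds shown, and "the series" means these compounds.

Measured compounds:
- compound 1, `CCc1cnc2c(C#N)c(N3CCC(c4ccccc4)CC3)ccn12`: 501 nM
- compound 2, `CCCc1nnc2c(C#N)c(N3CCC(c4ccccc4)CC3)ccn12`: 299 nM

Both were tested in a functional assay on CHO cells for positive allosteric modulation of metabotropic glutamate receptor 2 (Homo sapiens), read by GTPgammaS binding, with a stated time of 30 min; a higher number here means that more compound is needed for the effect, a lower number that less compound is needed. Compound 1 gives 501 nM and compound 2 gives 299 nM; compound 2 has the lower of the two numbers, but the gap to compound 1 lies within the scatter, so the two compounds cannot be told apart on these figures.

Compound 3, `N#Cc1c(N2CCC(c3ccccc3)CC2)ccn2c(CC3CC3)nnc12`, is not yet measured in this assay. It differs from compound 2 in one place: cyclopropyl in place of ethyl on a saturated chain carbon bound to an aromatic carbon. Among the compounds with values here, compound 1 and compound 2 differ in the core and in the chain at once, so no single-point step is available to guide the estimate. The change from ethyl to cyclopropyl is small in size and adds no donor or acceptor, and no step beyond the scatter is expected in this assay. Compound 3 is expected at about 250 nM, with a range from 100 nM to 650 nM. The estimated step of a 1.2-fold lower number from compound 2 to compound 3 (0.08 log units; within the scatter) is therefore meant to lie within the scatter.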

Compound 3, half-maximal effective concentration: 74 nM
Beside the measured number, compound 3's estimate is 3.4-fold (0.53 log units) above it; measured number outside the range, below it.
By their numbers in this assay, from the lowest: compound 3; then compounds 2 and 1 (each within the scatter of the next).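

Within the data shown here, this is the first step in this assay that can be read at a single place: cyclopropyl in place of ethyl on a saturated chain carbon bound to an aromatic carbon gives a 4.0-fold lower number from compound 2 to compound 3 (0.61 log units; beyond the scatter) and so moves the number beyond the scatter. It shows that this position is not indifferent to the group it carries, even when the change brings in only a three-membered non-aromatic ring of carbon and no hydrogen-bond donor or acceptor. No measurement shown here explains the step.

The compounds shown leave open whether the ring itself or simply the larger group goes with the step, a question that a butyl or isobutyl chain at this place would address. Also open, from the compounds shown here alone, is how a cyclobutyl or a methoxymethyl group would read here, and whether the step holds on the core of compound 1.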